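Replacing Bromo with Hydroxy on a Chalcone Scaffold

This account rests on a few compounds, and the source may have more. Where it says the series, first, only, none or still open, it means among the compounds named here.

Measured compounds:
compound 1, `CN(C)Cc1cc(C(=O)/C=C/c2ccc(Cl)cc2)cc(CN(C)C)c1O`, 10000 nM
compound 2, `CN(C)Cc1cc(C(=O)/C=C/c2ccc(F)cc2)cc(CN(C)C)c1O`, 20000 nM
compound 3, `CN(C)Cc1cc(C(=O)/C=C/c2ccc(Br)cc2)cc(CN(C)C)c1O`, 6310 nM

In a functional assay on cells (Tumor Cell line, Homo sapiens) for cytotoxicity (on this read-out lower numbers stand for stronger inhibition and higher numbers for weaker inhibition), compound 3 gives the lowest of the three numbers. Its nearest neighbour is compound 1, separated by a 1.6-fold lower number from compound 1 to compound 3 (0.20 log units; within the scatter), while compound 2 lies further off, by a 3.2-fold lower number from compound 2 to compound 3 (0.50 log units; beyond the scatter). The gap between compound 1 and compound 2 is a 2.0-fold higher number from compound 1 to compound 2 (0.30 log units; within the scatter).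

Compound 4 is `CN(C)Cc1cc(C(=O)/C=C/c2ccc(O)cc2)cc(CN(C)C)c1O`. Relative to compound 3 the change is hydroxy in place of bromo on an aromatic carbon. Among the measured compounds shown here, no measured step bears directly on it: the three measured steps all swap one halogen for another, and the only one beyond the scatter is the step from fluoro to bromo. Those steps show that the bromo compound sits at the low end of the halogen series, so leaving bromo for hydroxy is expected to move the number upward, tentatively toward the range of compound 2 or beyond it. Compound 4 is therefore expected at 20000 nM, with a range of 6300 nM to 63000 nM, and the expected step is a 3.2-fold higher number from compound 3 to compound 4 (0.50 log units; beyond the scatter).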

Compound 4, half-maximal inhibitory concentration: 39800 nM
For compound 4 the middle estimate is 2.0-fold (0.30 log units) below the measured one; low and high end bracket the measured number.
By their numbers in this assay, from the lowest: compounds 3, 1, 2 and 4 (each within the scatter of the next, the first and the last beyond it).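

In this assay, the step from 4-bromophenyl to 4-hydroxyphenyl shows that this position responds to leaving the halogens altogether, with a 6.3-fold higher number from compound 3 to compound 4 (0.80 log units; beyond the scatter), a larger step than any seen among the halogens. Hydroxy also stands clear of chloro, with a 4.0-fold higher number from compound 1 to compound 4 (0.60 log units; beyond the scatter), but not of fluoro, with a 2.0-fold higher number from compound 2 to compound 4 (0.30 log units; within the scatter), so the data separate compound 4 from compound 2 no better than the scatter allows. Hydroxy, the only group here that adds a hydrogen-bond donor and acceptor, thus gives a number that fluoro cannot be told apart from, and the halogens alone had not shown this.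

Nothing in the data shown explains these steps. As far as these compounds go, whether a methoxy group, an amine or a carboxylic acid at this position would stay near compound 4 or come closer to compound 3 remains open.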